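The compounds below may be only part of what the source reports. "The series", "measured", "known", "first", "only" and "open" are said of these compounds alone.

Among the measured compounds shown here, compound 2 `O=S(=O)(c1sccc1-c1ccccc1Oc1ccc(O)c(O)c1)N1CCN(C(=S)Nc2ccc(Cl)cc2)CC1` gives 2% in an assay for binding affinity to Apoptosis regulator Bcl-2 (Homo sapiens), read by fluorescence polarization, with stated times of 30 min and 20 min, tested at 100 uM (a lower number here means less inhibition, a higher number more inhibition at the concentration tested (going by the name of the read-out)), the lowest of the two numbers measured so far; compound 1 `O=C(Nc1ccc([N+](=O)[O-])cc1)N1CCN(S(=O)(=O)c2sccc2-c2ccccc2Oc2ccc(O)c(O)c2)CC1` gives 33%. Compound 3 `O=[N+]([O-])c1ccc(NC(=S)N2CCN(S(=O)(=O)c3sccc3-c3ccccc3Oc3ccc(O)c(O)c3)CC2)cc1` is compound 2 with nitro in place of chloro on an aromatic carbon. For the measured compounds named here, the only measured step, a number 31 percentage points lower from compound 1 to compound 2 (beyond the scatter), bears on this change only loosely, since it alters the group on the ring nitrogen in more than one way at once, exchanging a nitro-bearing ring for a chloro-bearing one. A rise is expected for compound 3, a number 13 percentage points higher from compound 2 to compound 3 (beyond the scatter), though smaller than that step, because compound 1 with the nitro group in place gives 33%. Compound 3 is therefore estimated at 15%, within 0% to 35%.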

Compound 3, a percentage reported as inhibition, at one concentration (the size of the read-out at that concentration, not a potency): 31%
Estimate against measurement, compound 3: 16 percentage points below, within the range that was stated.
By their numbers in this assay, from the lowest: compound 2; then compounds 3 and 1 (each within the scatter of the next).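

Placing nitro instead of chloro on the aromatic carbon para to a large group gives a number 29 percentage points higher from compound 2 to compound 3 (beyond the scatter) in this assay, so this single change at this position is enough to move the number beyond the scatter. With the nitro group kept, sulfur in place of the carbonyl oxygen gives a number 2 percentage points lower from compound 1 to compound 3 (within the scatter), so this exchange does not separate the two compounds. Nothing measured here explains either result.

On these data alone, it remains open where an amine or a methoxy group on this carbon would fall. As far as these compounds go, it is also open whether the sulfur-for-oxygen exchange would stay within the scatter with chloro in place of nitro.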